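The source may hold more compounds than are shown below. What is called first, only, known or untested is meant among the compounds shown, and "the series" means these compounds.

Measured compounds:
compound 1 `COc1ccccc1/C(=C\c1cn(C(C)=O)c2ccc(OCc3ccccc3)cc12)C(=O)O`, which in a functional assay on A549 cells (Homo sapiens) for cytotoxicity, read by MTT assay, with a stated time of 72 h (a lower number here means a stronger inhibitor, a higher number a weaker inhibitor), gives 57200 nM
compound 2 `COc1ccc(OC)c(/C(=C\c2cn(C(C)=O)c3ccc(OCc4ccccc4)cc23)C(=O)O)c1`, which in this assay gives 54500 nM

Compound 2 carries the lower of the two numbers, yet its gap to compound 1 is within the scatter, so the two values are not distinguished. The step to compound 3 `COc1cc(OC)cc(/C(=C\c2cn(C(C)=O)c3ccc(OCc4ccccc4)cc23)C(=O)O)c1` keeps every atom and rearranges the aryl group: 3,5-dimethoxyphenyl in place of 2,5-dimethoxyphenyl on a double-bonded chain carbon bound to a carbonyl carbon and a double-bonded chain carbon. Among the measured compounds shown here, one measured step bears on this ring: a 1.0-fold lower number from compound 1 to compound 2 (0.02 log units; within the scatter), the addition of a methoxy to the same aryl group, and it stayed within the scatter. Nothing measured here tells how moving a methoxy around that ring acts in this assay. Given that, no step beyond the scatter is expected in this assay from compound 2 to compound 3, in either direction, the expected step being a 1.0-fold lower number from compound 2 to compound 3 (0.02 log units; within the scatter). Compound 3 is therefore estimated at 52000 nM, with a range of 20000 nM to 140000 nM.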

Compound 3, half-maximal inhibitory concentration: 26000 nM
Beside the measured number, compound 3's estimate is 2.0-fold (0.30 log units) above it, within the range that was stated.
By their numbers in this assay, from the lowest: compound 3; then compounds 2 and 1 (each within the scatter of the next).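

In this assay, the aryl group on the double-bonded chain carbon now responds to where its methoxy groups sit: with the same atoms, 3,5-dimethoxyphenyl in place of 2,5-dimethoxyphenyl gives a 2.1-fold lower number from compound 2 to compound 3 (0.32 log units; beyond the scatter), a modest step but the first in the series beyond the scatter. Set against 2-methoxyphenyl, the same group gives a 2.2-fold lower number from compound 1 to compound 3 (0.34 log units; beyond the scatter), also modest, whereas the added methoxy in a 1.0-fold lower number from compound 1 to compound 2 (0.02 log units; within the scatter) did not separate the values. Among these three compounds, then, a second methoxy goes with a lower number only in the 3,5-dimethoxyphenyl arrangement, and no measurement here accounts for that difference.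

Still open, on these data alone, is whether a hydroxyl, an amine or a longer alkoxy chain in place of these methoxy groups would follow the same arrangement. As far as these compounds go, it is also open whether a single methoxy in the arrangement of compound 3 would be enough for the lower number.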